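An Isopropyl Amide in Place of the 3,4-Dichlorophenyl Amide

The compounds below may be only part of what the source reports. "The series", "measured", "known", "first", "only" and "open" are said of these compounds alone.

compound 1, `COc1cc(/C=C/C(=O)c2cccc(NC(=O)c3cc(Cl)cc(Cl)c3)c2)ccc1O`: 51%
compound 2, `COc1cc(/C=C/C(=O)c2cccc(NC(=O)c3ccc(Cl)cc3)c2)ccc1O`: 42%
compound 3, `COc1cc(/C=C/C(=O)c2cccc(NC(=O)c3ccc(Cl)c(Cl)c3)c2)ccc1O`: 5%

In a functional assay on HUVEC cells (Homo sapiens) for inhibition, tested at 5 ug/mL (a higher number here means a stronger effect of the compound at the concentration tested, a lower number a weaker effect), compound 1 gives 51%, compound 2 gives 42% and compound 3 gives 5%. Compound 3 stands lowest of the three: the step of a number 37 percentage points lower from compound 2 to compound 3 (beyond the scatter) and the step of a number 46 percentage points lower from compound 1 to compound 3 (beyond the scatter) are both beyond the scatter, so compound 3 is the weakest of the measured set. Compound 1 and compound 2 sit within the scatter of each other, as a number 9 percentage points lower from compound 1 to compound 2 (within the scatter) shows.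

Compound 4, `COc1cc(/C=C/C(=O)c2cccc(NC(=O)C(C)C)c2)ccc1O`, differs from compound 3 in that (isopropyl in place of 3,4-dichlorophenyl on a carbonyl carbon). Within the data shown here, both steps that lead into compound 3 were large losses, and they bear on the new step only in that the 3,4-dichlorophenyl leaves; no measured step exchanges an aromatic group for an alkyl group. The expectation therefore is that compound 4 moves back toward the values of the other amides, and its step from compound 3 is estimated as a number 25 percentage points higher from compound 3 to compound 4 (beyond the scatter). Compound 4 is estimated at 30%, within a range from 5% to 60%.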

Compound 4, a percentage reported as inhibition, at one concentration (the size of the read-out at that concentration, not a potency): 51%
The estimate for compound 4 lay 21 percentage points below the measured number, and the stated range covers the measured number.
By their numbers in this assay, from the lowest: compound 3; then compounds 2, 1 and 4 (each within the scatter of the next).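

In this assay, this place on the carbonyl carbon does not depend on an aromatic ring: isopropyl in place of 3,4-dichlorophenyl gives a number 46 percentage points higher from compound 3 to compound 4 (beyond the scatter), a large recovery. The isopropyl amide also stands level with both other chlorinated phenyl amides, with a number 9 percentage points higher from compound 2 to compound 4 (within the scatter) and no change at the digits printed from compound 1 to compound 4 (within the scatter). Among the four amides shown, the low number therefore belongs to the 3,4-dichlorophenyl group alone, and the loss seen earlier does not extend to a small alkyl group.

As far as these compounds go, whether a longer chain, a cyclopropyl ring or an amine-bearing chain at this place would hold the number at this level remains open. Nothing available accounts for why compound 3 stands apart from the other three amides.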